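The compounds below may be only part of what the source reports. "The series", "measured", "known", "first", "only" and "open" are said of these compounds alone.

Working notes on the series, all values from a functional assay on CCRF-CEM cells (Homo sapiens) for inhibition, read by cell counting, with a stated time of 3 days; on this read-out lower numbers stand for stronger inhibition and higher numbers for weaker inhibition.

Compound 1 `C=C(Br)C(=O)Nc1cccc(-c2cn3nc(-c4ccc(OCC)cc4)sc3n2)c1` gives 1400 nM in this assay. Compound 3 `C=C(Br)C(=O)Nc1cccc(-c2cn3nc(-c4ccc(C)cc4)sc3n2)c1` gives 1700 nM in this assay, the highest of the two numbers shown, with compound 1 its nearest neighbour; the only measured step, a 1.2-fold higher number from compound 1 to compound 3 (0.08 log units; within the scatter), is within the scatter. Compound 2 `COc1cccc(-c2nn3cc(-c4cccc(N)c4)nc3s2)c1` reaches only a limit in this assay, > 250000 nM, and that reading is the limit of > 250000 nM in this assay, at which 1 of the 3 values shown sits.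

Compound 4 `C=C(Br)C(=O)Nc1cccc(-c2cn3nc(Cc4ccc(OC)cc4)sc3n2)c1` differs from compound 3 by 4-methoxybenzyl in place of 4-methylphenyl on an aromatic carbon. Among the compounds with values here, the one measured step that bears on this position, a 1.2-fold higher number from compound 1 to compound 3 (0.08 log units; within the scatter), exchanged substituents on the 4-methylphenyl ring and produced no change beyond the scatter. Within the data shown here, no measured step covers the change from a 4-methylphenyl to a 4-methoxybenzyl, so the expectation rests on that single step alone. The expected step is a 1.5-fold higher number from compound 3 to compound 4 (0.17 log units; within the scatter), a small shift toward a higher number, not confidently beyond the scatter. For compound 4 the estimated value in this assay is 2500 nM, with a range from 800 nM to 8000 nM.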

Compound 4, half-maximal inhibitory concentration: 2300 nM
Compound 4: the middle estimate sits 1.1-fold (0.04 log units) above what was measured; measured number inside the range.
By their numbers in this assay, from the lowest: compounds 1, 3 and 4 (each within the scatter of the next). At a limit, above all of these: compound 2.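

In this assay the read-out does not separate 4-methoxybenzyl from 4-methylphenyl, a 1.4-fold higher number from compound 3 to compound 4 (0.13 log units; within the scatter), nor from 4-ethoxyphenyl, a 1.6-fold higher number from compound 1 to compound 4 (0.22 log units; within the scatter). The earlier step only exchanged one substituted phenyl group for another, whereas compound 4 shows that 4-methoxybenzyl, with its larger heavy-atom count, can also stand on this aromatic carbon with no shift beyond the scatter. Nothing measured here gives a reason for either step.

Still open, as far as these compounds go, is how this position responds to groups without an aromatic ring, such as an amine, a carboxylic acid or a longer alkyl chain. Compound 2 differs from the other compounds in more than one place, and its reading of > 250000 nM is a limit, so it isolates no single change.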